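The source may hold more compounds than are shown below. What is called first, only, known or untested is meant among the compounds shown, and "the series" means these compounds.

Compound 1 `Nc1scc(CN2CCN(c3cc(Cl)cc(Cl)c3)CC2)c1C(=O)c1ccc(Cl)cc1`: -69%
Compound 2 `Nc1scc(CN2CCN(c3ccc(F)cc3Cl)CC2)c1C(=O)c1ccc(Cl)cc1`: -39%
Compound 3 `Nc1scc(CN2CCN(c3cccc(F)c3)CC2)c1C(=O)c1ccc(Cl)cc1`: -86%

In a functional assay on CHO cells with adenosine receptor A1 (Homo sapiens) as the target, read by cAMP accumulation and immunoassay, with a stated time of 6 min, tested at 1 uM (on this read-out higher numbers stand for a weaker effect at the one concentration tested and lower numbers for a stronger effect), compound 3 gives the lowest of the three numbers, so on this read-out it shows the strongest effect of the set; compound 1 stands nearest to it and compound 2 furthest. Compound 4 `Nc1scc(CN2CCN(c3c(F)cccc3F)CC2)c1C(=O)c1ccc(Cl)cc1` has not yet been measured. It differs from compound 3 in one place: 2,6-difluorophenyl in place of 3-fluorophenyl on an amine nitrogen in a ring. Two measured steps change the same group on the same ring nitrogen and so bear on this one: a number 17 percentage points lower from compound 1 to compound 3 (beyond the scatter) and a number 47 percentage points lower from compound 2 to compound 3 (beyond the scatter). Of the three measured groups, the 2-chloro-4-fluorophenyl of compound 2 comes closest in name to the entering 2,6-difluorophenyl, and compound 2 gave the highest number. The account therefore expects compound 4 to give a number above that of compound 3, an estimated a number 31 percentage points higher from compound 3 to compound 4 (beyond the scatter). For compound 4 the expected value is -55%, within a range from -85% to -20%.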

Compound 4, a percentage reported as activity, at one concentration (the size of the read-out at that concentration, not a potency): -65%
Compound 4: middle estimate off by 10 percentage points, on the high side; measured number inside the range.
By their numbers in this assay, from the lowest: compound 3; then compounds 1 and 4 (each within the scatter of the next); then compound 2.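

In this assay, 2,6-difluorophenyl on the amine nitrogen in a ring gives a weaker effect than 3-fluorophenyl, with a number 21 percentage points higher from compound 3 to compound 4 (beyond the scatter) as the step, so a second fluorine with a changed pattern on this phenyl does not leave the read-out unchanged. Likeness in name to 2-chloro-4-fluorophenyl does not make the two groups read alike, as the step is a number 26 percentage points lower from compound 2 to compound 4 (beyond the scatter) and yet 2,6-difluorophenyl cannot be told apart from 3,5-dichlorophenyl, with a number 4 percentage points higher from compound 1 to compound 4 (within the scatter) as the step. No measurement shown here explains these differences.

The compounds shown leave open how a phenyl without halogen, or one bearing a methoxy group or a nitrile, would read at this position. They also leave open whether 2-fluorophenyl alone would stand with 3-fluorophenyl or with 2,6-difluorophenyl.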